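This account rests on a few compounds, and the source may have more. Where it says the series, first, only, none or still open, it means among the compounds named here.

Compound 1 `CC1=C(C(=O)C2CC2)C(c2ccco2)NC(=O)N1` gives 2% in an assay on membranes from CHO cells for displacement of a labelled ligand from adenosine receptor A1 (Homo sapiens), read by scintillation counting, with a stated time of 60 min, tested at 1 uM (on this read-out higher numbers stand for more inhibition at the one concentration tested (going by the name of the read-out) and lower numbers for less inhibition), and compound 2 `CC1=C(C(=O)C2CC2)C(c2cccs2)NC(=O)N1` gives 1%. Compound 1 stands nearest to compound 2, the step of a number 1 percentage points lower from compound 1 to compound 2 (within the scatter) lying within the scatter. Compound 3 `CCNC(=O)C1=C(C)NC(=O)NC1c1ccco1` has not yet been measured; it differs from compound 1 by ethylamino in place of cyclopropyl on a carbonyl carbon. For the measured compounds named here, no measured step touches the carbonyl carbon, and the only step measured concerns another place and is itself within the scatter, so no shift beyond the scatter is expected for a number 1 percentage points higher from compound 1 to compound 3 (within the scatter). Compound 3 is therefore estimated at 3%, with a range from -6% to 12%.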

Compound 3, a percentage reported as inhibition, at one concentration (the size of the read-out at that concentration, not a potency): 2%
The estimate for compound 3 lay 1 percentage points above the measured number; low and high end bracket the measured number.
By their numbers in this assay, from the lowest: compounds 2, 1 and 3 (each within the scatter of the next).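

For the compounds shown here, the first change at the carbonyl carbon, cyclopropylcarbonyl to ethylcarbamoyl, gives no change at the digits printed from compound 1 to compound 3 (within the scatter) in this assay, so this position joins the thiophen-2-yl for furan-2-yl change as a second place where a single change leaves the number within the scatter. Losing the three-membered ring and adding a hydrogen-bond donor here therefore brought no measurable gain in inhibition at the one concentration tested. Nothing available explains this result. Still open, from the compounds shown here alone, is whether a longer chain, a carboxylic acid or a cyclic amine on this carbonyl carbon would move the number beyond the scatter.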